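Mirror Image of a Weak Antiproliferative Lactone

This account rests on a few compounds, and the source may have more. Where it says the series, first, only, none or still open, it means among the compounds named here.

Compound 1, `CC1(C)[C@@H]2CC3=NCC(=O)O[C@@]3(C)[C@H]1C2`, is the weaker of the two compounds measured in a functional assay on PC-3 cells (Homo sapiens) for antiproliferative activity, read by sulforhodamine B assay, with a stated time of 48 h; on this read-out higher numbers stand for weaker inhibition and lower numbers for stronger inhibition: compound 1 gives 43000 nM, the highest of the two numbers, while compound 2, `CC(C)(C)OC(=O)NCCC[C@@H]1N=C2C[C@@H]3C[C@@H](C3(C)C)[C@]2(C)OC1=O`, gives 6600 nM, a gap that lies beyond the usual scatter. Compound 3, `CC1(C)[C@H]2CC3=NCC(=O)O[C@]3(C)[C@@H]1C2`, has not yet been measured. The change from compound 1 to compound 3 is the two compounds have the same atoms and bonds and differ only in configuration as drawn: 3 of 3 stereo elements differ (all stereocentres are inverted: mirror images); a stereocentre at a saturated ring carbon is drawn S in compound 1 and R in compound 3; a stereocentre at a saturated ring carbon is drawn S in compound 1 and R in compound 3; a stereocentre at a saturated ring carbon is drawn S in compound 1 and R in compound 3. Among the measured compounds shown here, no measured pair in this set shows how inverting every stereocentre moves the number in this assay, so the expected size of the step rests on the structural change alone, and compound 1 is already a weak inhibitor at 43000 nM. The step of a 1.2-fold higher number from compound 1 to compound 3 (0.07 log units; within the scatter) is expected to stay within the scatter, with no clear direction. Compound 3 is therefore estimated at 50000 nM, within a range from 15000 nM to 160000 nM.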

Compound 3, half-maximal inhibitory concentration: > 300000 nM
Compound 3 ended at the assay's limit; the forecaster's own chance of this, stated with the estimate: 25%; middle value at least 6.0-fold (0.77 log units) away from the limit.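

In this assay, a change of configuration alone carries a step beyond the scatter, an at least 6.9-fold higher number from compound 1 to compound 3 (0.84 log units; beyond the scatter), so the handedness of the shared core matters here, which compounds 1 and 2 could not show. Compound 3 gives > 300000 nM, which is a limit of the assay and not a number, so the step sets only a minimum size. With no atom or bond changed, the loss can be traced to the arrangement of the core alone: the fact that compounds 1 and 3 differ only in the configuration as drawn

The compounds shown leave open how far past that limit compound 3 lies, and so the true size of the step. They also leave open whether the same inversion would matter as much for compound 2, and how a free amine or a carboxylic acid at the end of its side chain would move the number.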